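The source may report more compounds than this note shows. Statements on the series, on what has been measured and on what is new or still open speak of the compounds shown alone.

Three compounds share one core and differ only in the group on the ring nitrogen. Compound 1 `CN(C(=O)c1ccccc1)c1ccc2[nH]c(-c3n[nH]c4ccccc34)cc2n1` gives 4850 nM in a functional assay on HL-60 cells (Homo sapiens) for antiproliferative activity, read by MTT assay, with a stated time of 72 h; on this read-out lower numbers stand for stronger inhibition and higher numbers for weaker inhibition; compound 2 `CN(c1ccc2[nH]c(-c3n[nH]c4ccccc34)cc2n1)S(=O)(=O)c1ccccc1` gives 3700 nM, and compound 3 `Cc1ccc(S(=O)(=O)N(C)c2ccc3[nH]c(-c4n[nH]c5ccccc45)cc3n2)cc1` gives 3030 nM. All three sit close together: a 1.3-fold lower number from compound 1 to compound 2 (0.12 log units; within the scatter), a 1.6-fold lower number from compound 1 to compound 3 (0.20 log units; within the scatter) and a 1.2-fold lower number from compound 2 to compound 3 (0.09 log units; within the scatter). Compound 4 `CN(c1ccc2[nH]c(-c3n[nH]c4ccccc34)cc2n1)S(=O)(=O)c1ccc(Cl)cc1` is the next step from compound 3, with chloro in place of methyl on an aromatic carbon. Among the compounds with values here, no measured step exchanges chloro for methyl; the nearest, a 1.2-fold lower number from compound 2 to compound 3 (0.09 log units; within the scatter), changed the same aromatic carbon and stayed within the scatter. On that basis compound 4 is expected to stay close to compound 3, a 1.0-fold lower number from compound 3 to compound 4 (0.00 log units; within the scatter), with no step beyond the scatter. Compound 4 is estimated at 3000 nM, between 1500 nM and 6500 nM.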

Compound 4, half-maximal inhibitory concentration: 770 nM
The estimate for compound 4 lay 3.9-fold (0.59 log units) above the measured number; measured number below the stated range.
By their numbers in this assay, from the lowest: compound 4; then compounds 3, 2 and 1 (each within the scatter of the next).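

The aromatic carbon of the sulfonyl's phenyl ring now proves sensitive to what it carries: methyl had left the number within the scatter, whereas chloro moves it beyond the scatter in both comparisons (a 3.9-fold lower number from compound 3 to compound 4 (0.59 log units; beyond the scatter)) and (a 4.8-fold lower number from compound 2 to compound 4 (0.68 log units; beyond the scatter)). The sulfonyl compound with chloro also separates from the benzoyl compound (a 6.3-fold lower number from compound 1 to compound 4 (0.80 log units; beyond the scatter)), which the unsubstituted and methyl sulfonyl compounds did not do. Nothing available accounts for the difference between chloro and methyl.

The compounds shown leave open whether bromo, fluoro or methoxy on the same aromatic carbon would follow chloro. They also leave open whether chloro on the benzoyl ring of compound 1 would bring a similar step.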